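Cytotoxicity notes on a cyclohexyloxy replacement in the series

The compounds below may be only part of what the source reports. "The series", "measured", "known", "first", "only" and "open" are said of these compounds alone.

Measured compounds:
compound 1 `Cc1cn(C2CCN(Cc3cncc(Oc4cccc(Cl)c4)c3)CC2)c(=O)[nH]c1=O` — > 64000 nM
compound 2 `Cc1ccc(Oc2cccc(CN3CCC(n4cc(C)c(=O)[nH]c4=O)CC3)c2)cc1` — > 64000 nM

In an ADME assay on MRC5 cells (Homo sapiens) for cytotoxicity, read by fluorescence and resazurin assay, with a stated time of 3 days (a lower number here means a stronger inhibitor, a higher number a weaker inhibitor), compound 1 returns only a limit, > 64000 nM. Compound 2 likewise returns only a limit, > 64000 nM. Both values sit at the limit of > 64000 nM in this assay, at which 2 of the 2 values shown sit, so compound 2 stands at the assay ceiling alongside compound 1, and the two values show the same outcome with nothing to separate them.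

Compound 3 `Cc1cn(C2CCN(Cc3cccc(OC4CCCCC4)c3)CC2)c(=O)[nH]c1=O` has not yet been measured in this assay. It differs from compound 2 in one place: cyclohexyl in place of 4-methylphenyl on an oxygen on an aromatic ring. The rest of the molecule is unchanged.

Going by the values given here, with both measured compounds at the limit, no measured step within the set is available for calibration. The step expected in this assay is a step that the limit leaves unreadable from compound 2 to compound 3, none beyond the scatter. Compound 3 is therefore estimated at 80000 nM, with a range from 32000 nM to 200000 nM, most likely again reported only as a limit.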

Compound 3, half-maximal inhibitory concentration: 23600 nM
Compound 3: middle estimate off by 3.4-fold (0.53 log units), on the high side; measured number outside the range, below it.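

In this assay, the group on this oxygen on an aromatic ring can shift the read-out: cyclohexyl in place of 4-methylphenyl gives an at least 2.7-fold lower number from compound 2 to compound 3 (0.43 log units; beyond the scatter). Going by these compounds alone, compound 3 is the first compound in the set with a value that is not a limit, so cytotoxicity can be brought into readable range by a change at this one place. The step has only a minimum size because compound 2 carries a limit: the limit of > 64000 nM in this assay, at which 2 of the 3 values shown sit.

A single pair cannot separate the loss of the aromatic ring from the other differences between 4-methylphenyl and cyclohexyl. Going by these compounds, how an open butyl chain or a ring carrying an amine on the same oxygen would read in this assay remains open, as does whether the step holds on other parts of the series.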